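The source may report more compounds than this note shows. Statements on the series, on what has been measured and on what is new or still open speak of the compounds shown alone.

Measured so far in a functional assay on NCI-H2122 cells (Homo sapiens) for inhibition, read by microscopy, with a stated time of 10 days; a lower number here means a stronger inhibitor, a higher number a weaker inhibitor:

compound 1, `Cn1nc(-c2ccccc2)c2c1OC(N)=C(C#N)C2c1ccccc1`: > 10000 nM, which is a limit of this assay and not a number the limit of > 10000 nM in this assay, at which 1 of the 2 values shown sits.
compound 2, `Cn1nc(-c2ccccc2)c2c1OC(N)=C(C#N)C2c1ccc(C(F)(F)F)cc1`: 4100 nM

Going by the values given here, compound 2 is the only compound of this set with a number in this assay; the remaining value is a limit. Among the compounds with values here, the one measured step, an at least 2.4-fold lower number from compound 1 to compound 2 (0.38 log units; beyond the scatter), covers the introduction of trifluoromethyl onto an otherwise unsubstituted aromatic carbon.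

Compound 3, `CC(C)c1ccc(C2C(C#N)=C(N)Oc3c2c(-c2ccccc2)nn3C)cc1`, differs from compound 2 by isopropyl in place of trifluoromethyl on an aromatic carbon. The measured step does not bear directly on this exchange: it compares hydrogen with trifluoromethyl, not one substituent with another at the same place. What it does show is that a group at this position, para to a large group, moves the result out of the limit region into the measurable range. Within the data shown here, with no step that tells how isopropyl compares with trifluoromethyl, the exchange is taken as neutral within the scatter. The step is expected to be a 1.0-fold lower number from compound 2 to compound 3 (0.01 log units; within the scatter). Compound 3 is therefore estimated at 4000 nM, between 1500 nM and 12000 nM.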

Compound 3, half-maximal inhibitory concentration: 5400 nM
Estimate against measurement, compound 3: 1.4-fold (0.13 log units) below; the measured number falls inside the stated range.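

In this assay, the exchange at this place, para to a large group, gives a 1.3-fold higher number from compound 2 to compound 3 (0.12 log units; within the scatter). Trifluoromethyl and isopropyl therefore cannot be told apart here, even though one carries fluorine and the other only carbon, so a measurable number at this place does not depend on fluorine in the group. Against hydrogen the reading is weaker, with an at least 1.8-fold lower number from compound 1 to compound 3 (0.26 log units; that floor lies within the scatter), so this step alone does not establish a gain for isopropyl, and compound 1 offers a limit, not a number, as its reference point: the limit of > 10000 nM in this assay, at which 1 of the 3 values shown sits.

Open, from the compounds shown here alone, is how wide the tolerance at this place runs, and whether an amine, a carboxylic acid, a methoxy group or a longer alkyl chain would stay level with compound 2 and compound 3 or move the number clearly in either direction. Also open, going by these compounds, is how large the true difference from the unsubstituted compound 1 is, and whether any substituent at this place can bring the number far below the range seen so far.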